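The source may hold more compounds than are shown below. What is called first, only, known or untested is meant among the compounds shown, and "the series" means these compounds.

Compound 1, with the structure `N#Cc1ccc(Nc2nccc(Oc3ccc(-c4ccc(C#N)cc4)c(F)c3F)n2)cc1`, gives in a functional assay on MT4 cells (Homo sapiens) for cytotoxicity, read by MTT assay, with a stated time of 5 days (on this read-out lower numbers stand for higher toxicity in this test and higher numbers for lower toxicity in this test), only the limit > 294000 nM, not a number.
Compound 2, with the structure `N#Cc1ccc(Nc2nccc(Oc3ccc(-c4ccc(C#N)cc4F)cc3F)n2)cc1`, gives in this assay only the limit > 294000 nM, again not a number.
Compound 3, with the structure `COc1cc(Oc2ccnc(Nc3ccc(C#N)cc3)n2)ccc1-c1ccc(C#N)cc1`, gives in this assay only the limit > 298000 nM, once more not a number.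

All three compounds thus stand at the upper edge of what this assay can report. Two of them sit at the limit of > 294000 nM in this assay, at which 2 of the 3 values shown sit, while compound 3 alone sits at the limit of > 298000 nM in this assay, at which 1 of the 3 values shown sits; these two limits differ only by the concentration reached in the test, not by any measured difference between the compounds. Compound 3 therefore stands at the top of the numbers shown, together with the other two, with no value below a limit anywhere in the set.

Compound 4, with the structure `N#Cc1ccc(Nc2nccc(Oc3ccc(-c4ccc(C#N)cc4)c(C(F)(F)F)c3)n2)cc1`, has not been measured. It differs from compound 3 in this way: trifluoromethyl in place of methoxy on an aromatic carbon. Nothing in the three measured compounds points to a step in either direction beyond the scatter, as none of them gave a number below its limit. Compound 4 is therefore expected to sit at the limit as well, with the step from compound 3 estimated as an at least 1.0-fold lower number from compound 3 to compound 4 (0.01 log units; that floor lies within the scatter). The estimate for compound 4 in this assay is 290000 nM, within a range from 100000 nM to 300000 nM.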

Compound 4, half-maximal cytotoxic concentration: > 273000 nM
Compound 4 was reported as a limit; the forecaster's own chance of this, stated with the estimate: 85%; the middle value does not contradict the limit.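

Compound 3 and compound 4 both give only a limit in this assay, not a number, so no step can be read between them. The compounds shown leave open at what concentration any of them would turn toxic in this assay, and whether trifluoromethyl in place of methoxy changes that concentration.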